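The source may hold more compounds than are shown below. What is called first, only, known or untested is meant among the compounds shown, and "the series" means these compounds.

Of the compounds shown here, two from this series have been measured, and a third awaits its number. Compound 1 `CC(C)[C@H]1CC[C@@]2(CO2)[C@H]2C(=O)OCC(C(=O)OCc3ccc(-c4ccc([N+](=O)[O-])cc4)o3)=C[C@H]12` carries an ester-linked side arm; compound 2 `CC(C)[C@H]1CC[C@@](O)(CI)[C@H]2C(=O)OCC(C(=O)O)=C[C@H]12` is a simpler acid bearing an iodomethyl group on the shared core. In a functional assay on NAMALVA cells (Homo sapiens) for inhibition, with a stated time of 72 h (a higher number here means a weaker inhibitor, a lower number a stronger inhibitor), compound 1 gives 1190 nM, while compound 2 gives 3260 nM. Compound 2 therefore stands at the higher of the two numbers, and its gap to compound 1 lies beyond the usual scatter of repeated measurements, so compound 2 is the weaker of the pair.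

Compound 3 `CC(C)[C@H]1CC[C@@](O)(CCl)[C@H]2C(=O)OCC(C(=O)O)=C[C@H]12` differs from compound 2 in one place: chloro in place of iodo on a saturated chain carbon bound to a saturated ring carbon. For the measured compounds named here, no other pair shows a halogen swap of this kind, so there is no measured step to lean on. A change of one halogen for another on a saturated chain carbon is a modest alteration of the structure, and the expectation is a small step of a 1.1-fold higher number from compound 2 to compound 3 (0.03 log units; within the scatter), likely within or just at the edge of the scatter, with no firm direction. On that basis compound 3 is estimated to give 3500 nM in this assay, with a range from 1500 nM to 8000 nM.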

Compound 3, half-maximal inhibitory concentration: 320 nM
For compound 3 the middle estimate is 11-fold (1.04 log units) above the measured one, outside the stated range (below it).
By their numbers in this assay, from the lowest: compound 3; then compound 1; then compound 2.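

In this assay, replacing iodomethyl with chloromethyl, on a saturated chain carbon bound to a saturated ring carbon, gives a 10-fold lower number from compound 2 to compound 3 (1.01 log units; beyond the scatter) and so a large change beyond the scatter from a swap of one halogen atom. This shows that the number at this position is highly sensitive to which halogen is present, something the earlier pair could not reveal, as compound 1 and compound 2 differ in more than one place. Nothing in the data at hand explains why so small a structural change has so large an effect.

Going by these compounds, with only iodo and chloro to compare, it remains open how other groups at this place would behave, such as bromomethyl, fluoromethyl, or a plain methyl that carries no halogen at all. For the compounds shown here, the step is also seen only on the simple carboxylic acid, so it remains open whether chloro in place of iodo would have a similar effect in a compound carrying an ester-linked side arm like that of compound 1.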